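The source may hold more compounds than are shown below. What is called first, only, known or untested is meant among the compounds shown, and "the series" means these compounds.

In a functional assay on PC-3 cells (Homo sapiens) for antiproliferative activity, read by MTT assay, with a stated time of 24 h (on this read-out higher numbers stand for weaker inhibition and lower numbers for stronger inhibition), three amide esters on one shared core have been read. Compound 1 `CCn1c(C(=O)N[C@@H](C)C(=O)OC)ccc1C(CC)(CC)c1ccc(OCS(=O)(=O)c2ccccc2)c(C)c1` gives > 50000 nM, which is a limit of the assay and not a number. Compound 2 `CCn1c(C(=O)NCC(=O)OC)ccc1C(CC)(CC)c1ccc(OCS(=O)(=O)c2ccccc2)c(C)c1` gives > 50000 nM, again a limit. Among the measured compounds shown here, compound 3 `CCn1c(C(=O)NCCC(=O)OC)ccc1C(CC)(CC)c1ccc(OCS(=O)(=O)c2ccccc2)c(C)c1` gives 40400 nM, the only true number of the three.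

Compound 4 `CCn1c(C(=O)N[C@@H](CC(=O)OC)C(=O)OC)ccc1C(CC)(CC)c1ccc(OCS(=O)(=O)c2ccccc2)c(C)c1` departs from compound 3 by methoxycarbonyl in place of hydrogen on a saturated chain carbon bound to an amide-type nitrogen and a saturated chain carbon. This turns 2-(methoxycarbonyl)ethyl into 1,2-bis(methoxycarbonyl)ethyl, a group that joins the side chain of compound 3 to the 1-(methoxycarbonyl)ethyl of compound 1.

For the measured compounds named here, the steps that bear on this are an at least 1.2-fold lower number from compound 1 to compound 3 (0.09 log units; that floor lies within the scatter) and an at least 1.2-fold lower number from compound 2 to compound 3 (0.09 log units; that floor lies within the scatter), both floors within the scatter, and a step that the two limits leave unreadable from compound 1 to compound 2. None of them shows a change beyond the scatter, so no step beyond the scatter is expected in this assay. The expected step is a 1.1-fold higher number from compound 3 to compound 4 (0.05 log units; within the scatter). For compound 4 the estimated value is 45000 nM, with an expected range of 20000 nM to 80000 nM.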

Compound 4, half-maximal inhibitory concentration: 6490 nM
For compound 4 the middle estimate is 6.9-fold (0.84 log units) above the measured one, outside the stated range (below it).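

In this assay, among the compounds shown here, methoxycarbonyl in place of hydrogen on a saturated chain carbon bound to an amide-type nitrogen and a saturated chain carbon gives a 6.2-fold lower number from compound 3 to compound 4 (0.79 log units; beyond the scatter), the first readable step to lie beyond the scatter. Compound 4, which alone carries 1,2-bis(methoxycarbonyl)ethyl, also stands apart from the two shorter esters, with an at least 7.7-fold lower number from compound 2 to compound 4 (0.88 log units; beyond the scatter) and an at least 7.7-fold lower number from compound 1 to compound 4 (0.88 log units; beyond the scatter). Both of these steps start from a limit of the assay, held by compound 1 and compound 2, and are floors rather than sizes: the limit of > 50000 nM in this assay, at which 2 of the 4 values shown sit.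

Going by these compounds, whether a carboxylic acid or an amine in place of the added methoxycarbonyl would read the same stays open. So does the effect of a longer chain carrying that ester, or of the opposite configuration at that chain carbon.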